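The compounds below may be only part of what the source reports. "The series", "measured", "known", "first", "only" and "open" are said of these compounds alone.

Measured compounds:
- compound 1 `COc1ccc2nc(C)cc(NCc3ccccc3)c2c1`: 28600 nM
- compound 2 `COc1ccc2nc(C)cc(NCc3ccc(C(C)(C)C)cc3)c2c1`: 7000 nM
- compound 3 `COc1ccc2nc(C)cc(NCc3cccc(N(C)C)c3)c2c1`: 14000 nM

In a functional assay on MCF-10A cells (Homo sapiens) for antiproliferative activity, with a stated time of 48 h (on this read-out higher numbers stand for an effect only at larger amounts of compound and lower numbers for an effect already at smaller amounts), compound 1 gives 28600 nM, the highest number of the three, and both of its measured neighbours sit lower. The next analogue, compound 4 `COc1ccc2nc(C)cc(NCc3ccccc3CO)c2c1`, keeps the core of compound 1 and carries one change: hydroxymethyl in place of hydrogen on an aromatic carbon, ortho to a large group (hydroxymethyl in place of hydrogen on an aromatic carbon).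

Among the compounds with values here, two measured steps bear on this change, since each also replaces hydrogen on an aromatic carbon of the same ring. With tert-butyl there is a 4.1-fold lower number from compound 1 to compound 2 (0.61 log units; beyond the scatter), and with dimethylamino there is a 2.0-fold lower number from compound 1 to compound 3 (0.31 log units; beyond the scatter). Both steps are modest and point the same way. Neither places its group ortho to a large group, however, and hydroxymethyl resembles neither group, so they are only a loose guide. Within the data shown here, no measured compound carries a substituent in that place.

A small move toward a lower number in this assay is therefore expected, possibly none beyond the scatter. The expected change is a 1.6-fold lower number from compound 1 to compound 4 (0.20 log units; within the scatter). For compound 4 the estimated value is 18000 nM, with an expected range from 8000 nM to 38000 nM.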

Compound 4, half-maximal effective concentration: 25900 nM
Compound 4: middle estimate off by 1.4-fold (0.16 log units), on the low side; the measured number falls inside the stated range.
By their numbers in this assay, from the lowest: compounds 2, 3, 4 and 1 (each within the scatter of the next, the first and the last beyond it).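

In this assay, hydroxymethyl on an aromatic carbon, ortho to a large group, gives a 1.1-fold lower number from compound 1 to compound 4 (0.04 log units; within the scatter), so this change leaves no effect that can be told apart from the usual scatter. Within the data shown here, it is the first replacement of hydrogen on this six-membered aromatic ring whose step stays within the scatter, whereas the tert-butyl change gave a 4.1-fold lower number from compound 1 to compound 2 (0.61 log units; beyond the scatter) and the dimethylamino change gave a 2.0-fold lower number from compound 1 to compound 3 (0.31 log units; beyond the scatter), both beyond it; replacing hydrogen on this ring therefore does not always shift the number, although those two groups also sit in other places than hydroxymethyl does. The data offer no measurement that would explain why this step is so small.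

Hydroxymethyl is the only group at this place among the compounds shown, so it remains open whether the flat result belongs to the place or to the group, and a carboxylic acid, an aminomethyl group or a longer chain such as hydroxyethyl in the same spot would bear on that. As far as these compounds go, it is equally open whether hydroxymethyl would behave the same way at the places that hold tert-butyl and dimethylamino.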